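The source may report more compounds than this note shows. Statements on the series, on what has been measured and on what is new or still open speak of the compounds shown alone.

Of the compounds shown here, two have been tested so far in a functional assay on cells (Platelet, Bos taurus) for inhibition; on this read-out higher numbers stand for weaker inhibition and lower numbers for stronger inhibition. Compound 1 `C=C1C(=O)O[C@@H]2/C=C(\C)CC[C@H]3O[C@]3(C)CC[C@@H]12` gives 121000 nM in this assay. Compound 2 `C=C1C(=O)O[C@@H]2/C=C(/CO)CC[C@H](OCC)C3=C[C@@H](OC3=O)[C@@H]12` gives 3520 nM in this assay. Of these two numbers, compound 2 has the lower one, and its gap to compound 1 lies well beyond the usual scatter of repeated measurements, so compound 2 is the stronger inhibitor of the pair.

Compound 3 `C=C1C(=O)O[C@@H]2/C=C(/COC(C)=O)CC[C@H](OCC)C3=C[C@@H](OC3=O)[C@@H]12` has not yet been measured. It differs from compound 2 in a single place: acetyl in place of hydrogen on an oxygen on a saturated carbon. Put another way, the hydroxymethyl group of compound 2 becomes an acetoxymethyl group, and everything else, including the shared core, stays as it is. Among the measured compounds shown here, no measured pair in this set shows what such a change does in this assay, so there is no earlier step to lean on. For the measured compounds named here, since only one group is altered, compound 3 is expected to remain close to compound 2, with a step of a 1.4-fold lower number from compound 2 to compound 3 (0.15 log units; within the scatter) that may well fall within the scatter. In this assay compound 3 is expected to give about 2500 nM, within a range from 800 nM to 8000 nM.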

Compound 3, half-maximal inhibitory concentration: 2040 nM
Estimate against measurement, compound 3: 1.2-fold (0.09 log units) above, within the range that was stated.
By their numbers in this assay, from the lowest: compounds 3 and 2 (each within the scatter of the next); then compound 1.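

Acetyl in place of hydrogen on an oxygen on a saturated carbon, which turns hydroxymethyl into acetoxymethyl, is the first change in this series that can be read on its own, and in this assay it amounts to a 1.7-fold lower number from compound 2 to compound 3 (0.24 log units; within the scatter). With the two numbers inside the scatter, the assay does not separate compound 2 from compound 3, so at this place the hydrogen on the oxygen can give way to an acetyl group without a measurable change in inhibition on these cells. Nothing measured here gives a reason for this result.

This is a single pair on a single core, so only hydroxymethyl and acetoxymethyl can be compared at this place, and the pair says nothing about how far the same freedom extends. A longer acyl chain such as butanoyl on the same oxygen, a methyl ether, or a carboxylic acid or an amine on that carbon could each give a number that stays with these two or one that moves clearly away from them.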